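Amide-to-Amine Switch on a Bile Acid Receptor Agonist Series

The compounds below may be only part of what the source reports. "The series", "measured", "known", "first", "only" and "open" are said of these compounds alone.

Measured so far:
Compound 1, `CC(C)c1onc(-c2c(Cl)cccc2Cl)c1COc1ccc(NC(=O)c2ccc(C(=O)O)cc2)c(C(F)(F)F)n1`, gives 48%.
Compound 2, `CC(C)c1onc(-c2c(Cl)cccc2Cl)c1COc1ccc(N(C)C(=O)c2cccc(C(=O)O)c2)c(C(F)(F)F)n1`, gives 55%.
Compound 3, `CC(C)c1onc(-c2c(Cl)cccc2Cl)c1COc1ccc(NCc2ccc(C(=O)O)cc2)c(C(F)(F)F)n1`, gives 45%.

All three compounds share one core and differ only in the group hanging from the ring nitrogen of the shared core. In a functional assay on HEK293 cells for agonist activity at Bile acid receptor (Homo sapiens), read by a luciferase reporter (a higher number here means a larger maximal response, a lower number a smaller maximal response), compound 3 gives 45%, the lowest of the three numbers, though its nearest neighbour compound 1 gives 48% and compound 2 gives 55%, both within the usual scatter of compound 3.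

Compound 4, `CC(C)c1onc(-c2c(Cl)cccc2Cl)c1COc1ccc(N(C)Cc2cccc(C(=O)O)c2)c(C(F)(F)F)n1`, has not yet been measured. It differs from compound 3 in one place: (3-carboxybenzyl)(methyl)amino in place of (4-carboxybenzyl)amino on an aromatic carbon.

Among the compounds with values here, one measured step bears on the path from compound 3: a number 3 percentage points lower from compound 1 to compound 3 (within the scatter). That step replaced an amide by an amine and left the response essentially unchanged. Within the data shown here, no measured step separates compound 1 from compound 2 in only one place, so the combined effect of adding a methyl on the nitrogen and moving the carboxyl is known only through their two values. Taken together, nothing here points to a change beyond the scatter. Compound 4 is therefore expected to give about 50%, between 36% and 64%, a step of a number 5 percentage points higher from compound 3 to compound 4 (within the scatter) from compound 3.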

Compound 4, largest response reached (reported as efficacy), in percent of the reference or control that the assay uses: 58%
For compound 4 the middle estimate is 8 percentage points below the measured one; measured number inside the range.
By their numbers in this assay, from the lowest: compounds 3, 1, 2 and 4 (each within the scatter of the next, the first and the last beyond it).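

In this assay, within the data shown here, the exchange at this aromatic carbon gives the first step that lies beyond the scatter: a number 13 percentage points higher from compound 3 to compound 4 (beyond the scatter), a modest step, with (3-carboxybenzyl)(methyl)amino in place of (4-carboxybenzyl)amino. Replacing the carbonyl with a plain benzyl carbon also holds up on a second background, since a number 3 percentage points higher from compound 2 to compound 4 (within the scatter) stays within the scatter, as the earlier amide-to-amine step did, and the wider change in a number 10 percentage points higher from compound 1 to compound 4 (within the scatter) stays within it as well. The data shown offer no measurement that accounts for the step beyond the scatter.

That step changes two things at once, a methyl on the nitrogen and the place of the carboxylic acid on the benzyl ring, so it cannot yet be assigned to either one. A compound carrying (3-carboxybenzyl)amino or (4-carboxybenzyl)(methyl)amino would separate the two, while an ethyl on the nitrogen, or a tetrazole in place of the carboxylic acid, would test how much change this position accepts.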